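Ester to acid on a chromone core: expected cytotoxicity

The compounds below may be only part of what the source reports. "The series", "measured", "known", "first", "only" and "open" are said of these compounds alone.

Measured compounds:
compound 1 `COC(=O)c1c(-c2cc(OC)cc(OC)c2)oc2ccccc2c1=O` — 6.99 ug/mL
compound 2 `COC(=O)c1c(-c2ccc([N+](=O)[O-])cc2)oc2ccccc2c1=O` — > 25 ug/mL
compound 3 `COc1cc(OC)cc(-c2oc3ccccc3c(=O)c2C(=O)O)c1` — > 25 ug/mL

In a functional assay on HT-29 cells (Homo sapiens) for cytotoxicity, read by MTT assay, with a stated time of 6 days (on this read-out higher numbers stand for an effect only at larger amounts of compound and lower numbers for an effect already at smaller amounts), compound 1 gives 6.99 ug/mL. Compound 3 `COc1cc(OC)cc(-c2oc3ccccc3c(=O)c2C(=O)O)c1` reaches only a limit in this assay, > 25 ug/mL, which is not a number. Compound 2 `COC(=O)c1c(-c2ccc([N+](=O)[O-])cc2)oc2ccccc2c1=O` likewise reaches only a limit, > 25 ug/mL. The change from compound 1 to compound 3 is hydrogen in place of methyl on an oxygen next to a carbonyl group and the step it made is an at least 3.5-fold higher number from compound 1 to compound 3 (0.55 log units; beyond the scatter).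

Compound 4 `O=C(O)c1c(-c2ccc([N+](=O)[O-])cc2)oc2ccccc2c1=O` is not yet measured. For the measured compounds named here, it differs from compound 2 by hydrogen in place of methyl on an oxygen next to a carbonyl group, the same change, at the same place, as the one from compound 1 to compound 3. The difference between the two cores, compound 1 against compound 2, is not broken down here.

Because compound 2 already sits at the limit of > 25 ug/mL in this assay, at which 2 of the 3 values shown sit, and because the same change gave an at least 3.5-fold higher number from compound 1 to compound 3 (0.55 log units; beyond the scatter), the expected step is a step that the limit leaves unreadable from compound 2 to compound 4. Compound 4 is therefore estimated at 60 ug/mL, between 25 ug/mL and 250 ug/mL, most likely reported as a limit only.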

Compound 4, concentration for half-maximal effect: > 25 ug/mL
Compound 4 ended at the assay's limit (the forecaster's own chance of this, stated with the estimate: 90%); the middle value does not contradict the limit.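

Compound 2 and compound 4 both end at a limit rather than a number, so no step can be read between them, because the size of the change stays hidden: the limit of > 25 ug/mL in this assay, at which 3 of the 4 values shown sit.

The compounds shown leave open how large the change from methoxycarbonyl to carboxy is on the core of compound 2, and whether it matches the change on the core of compound 1.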